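The source may hold more compounds than are shown below. What is called first, only, known or untested is meant among the compounds shown, and "the series" means these compounds.

Compound 3, with the structure `CN(C)c1ccc(C2CC(c3ccc(-n4cncn4)cc3)=NN2C(=O)c2cc(Cl)cc(Cl)c2)cc1`, gives 8.4% in a functional assay on NCI-H1975 cells (Homo sapiens) for inhibition, read by sulforhodamine B assay, tested at 10 uM; a lower number here means less inhibition, a higher number more inhibition at the concentration tested (going by the name of the read-out). Among the three compounds measured so far it stands second highest. Compound 1, with the structure `CN(C)c1ccc(C2CC(c3ccc(-n4cncn4)cc3)=NN2)cc1`, gives -3.3% in this assay, and compound 2, with the structure `CN1CCN(c2ccc(C3=NN(C(=O)c4ccc(C(F)(F)F)cc4)C(c4ccc(N(C)C)cc4)C3)cc2)CC1`, gives 93.2%. Going by the values given here, the one single-point step measured so far, a number 11.7 percentage points higher from compound 1 to compound 3 (beyond the scatter), adds an acyl group to the ring nitrogen.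

Compound 4, with the structure `CN(C)c1ccc(C2CC(c3ccc(-n4cncn4)cc3)=NN2C(=O)c2ccc(C(F)(F)F)cc2)cc1`, keeps that acyl group but changes the aromatic ring on it: 4-(trifluoromethyl)phenyl in place of 3,5-dichlorophenyl on a carbonyl carbon. Among the compounds with values here, no measured step swaps one aromatic ring for another on this carbonyl carbon, so the available steps bear on the change only indirectly. Compound 2 carries the same 4-(trifluoromethyl)phenyl carbonyl and gives a high number, yet it differs from compound 4 in other places as well, so its value can only hint. The expected step is therefore small to moderate upward, a number 11.6 percentage points higher from compound 3 to compound 4 (beyond the scatter), and compound 4 is estimated at 20%, within a range from -5% to 60%.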

Compound 4, a percentage reported as inhibition, at one concentration (the size of the read-out at that concentration, not a potency): 11.5%
Beside the measured number, compound 4's estimate is 8.5 percentage points above it, within the range that was stated.
By their numbers in this assay, from the lowest: compound 1; then compounds 3 and 4 (each within the scatter of the next); then compound 2.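

In this assay the ring on the carbonyl carbon makes little difference at this position (a number 3.1 percentage points higher from compound 3 to compound 4 (within the scatter)), and the acylated compound with 4-(trifluoromethyl)phenyl still stands only modestly above the free ring nitrogen (a number 14.8 percentage points higher from compound 1 to compound 4 (beyond the scatter)). With that acyl group held fixed, the large change comes from a different place, the group on the aromatic carbon, where 1H-1,2,4-triazol-1-yl replaces 4-methylpiperazin-1-yl (a number 81.7 percentage points lower from compound 2 to compound 4 (beyond the scatter)). No evidence is available that explains either result.

On these data alone, it remains open whether 4-methylpiperazin-1-yl would give a similarly high number with 3,5-dichlorophenyl on the carbonyl carbon. As far as these compounds go, it is also open how a morpholine ring or a primary amine would behave in place of the piperazine on that aromatic carbon.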